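The source may hold more compounds than are shown below. What is called first, only, known or untested is meant among the compounds shown, and "the series" means these compounds.

Compound 1 `CCCCc1cc2c(=O)c(-c3ccc(C(F)(F)F)cc3)c(C)[nH]c2cc1OCCOc1ccccc1` and compound 2 `CCCCc1cc2c(=O)c(-c3ccc(OC(F)(F)F)cc3)c(C)[nH]c2cc1OCCOc1ccccc1` share one core and differ in a single group on an aromatic carbon. Within the data shown here, in an ADME assay on J774 cells (Mus musculus) for antiproliferative activity, with a stated time of 72 h (a lower number here means that less compound is needed, a higher number that more compound is needed for the effect), compound 1 gives 20000 nM, and compound 2 gives 20000 nM, so compound 2 stands level with its only measured neighbour.

Compound 3 `CCCCc1cc2c(=O)c(-c3ccc(Cl)cc3C)c(C)[nH]c2cc1OCCOc1ccccc1` keeps the shared core but replaces the whole aryl group of compound 2: 4-chloro-2-methylphenyl in place of 4-(trifluoromethoxy)phenyl on an aromatic carbon. In words, 4-chloro-2-methylphenyl sits in place of 4-(trifluoromethoxy)phenyl.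

Among the measured compounds shown here, only one measured step bears on this change, no change at the digits printed from compound 1 to compound 2 (within the scatter), in which trifluoromethoxy took the place of trifluoromethyl on that aryl group. It is a thin guide. For the measured compounds named here, the 4-chloro-2-methylphenyl group appears in no measured compound, and a single step cannot show a trend. Going by the values given here, still, it is the only evidence available, and it offers no reason to expect movement in either direction. The estimate is a 1.1-fold lower number from compound 2 to compound 3 (0.05 log units; within the scatter), so no step beyond the scatter is expected in this assay. On these data alone, the range is kept wide because the new group is untested. For compound 3 the estimated value is 18000 nM, with an expected range of 7000 nM to 30000 nM.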

Compound 3, half-maximal effective concentration: > 21000 nM
Compound 3: a limit, no number; the forecaster's own chance of this, stated with the estimate: 30%; middle value at least 1.1-fold (0.06 log units) from the limit.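

In this assay, the result for compound 3 is a limit of the assay and not a number: the limit of > 21000 nM in this assay, at which 1 of the 3 values shown sits. Measured against this limit, the replacement gives an at least 1.0-fold higher number from compound 2 to compound 3 (0.02 log units; that floor lies within the scatter), and the exchange starting from the 4-(trifluoromethyl)phenyl group gives an at least 1.0-fold higher number from compound 1 to compound 3 (0.02 log units; that floor lies within the scatter). Among these compounds, compounds 1 and 2 showed only that one fluorinated group at the para end of the aryl ring could stand in for another, whereas compound 3 extends this to a different aryl group, 4-chloro-2-methylphenyl, and here too the step stays within the scatter, with no sign that less compound is needed for the effect.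

On these data alone, since all three compounds keep an aryl group without an ionisable substituent on the shared core, the effect of an amine or a carboxylic acid on that ring remains open, as does that of a saturated ring or a simple methyl group in place of the whole aryl group. The butyl chain and the phenoxyethoxy chain also stay the same throughout, so what a shorter chain or an added amine at either place would do is equally unknown.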